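Ester chain variation in the shared core, compound 4

A few compounds are considered here, and "the series" means these few. Any claim that something is new, unique, unknown or untested is made for them only; others in the source may bear on it.

Compound 3 `CCC(C)OC(=O)C1=C(C)NC(=O)NC1c1ccco1` gives the lowest number of the three in an assay on membranes from HEK293 cells for displacement of a labelled ligand from adenosine receptor A2b (Homo sapiens), read by scintillation counting, with a stated time of 30 min (on this read-out higher numbers stand for weaker inhibition and lower numbers for stronger inhibition), at 84.3 nM; compound 1 `CC1=C(C(=O)OCC(C)C)C(c2ccoc2)NC(=O)N1` gives 326 nM and compound 2 `CC1=C(C(=O)OCc2ccccc2)C(c2ccoc2)NC(=O)N1` gives 6650 nM. Compounds 1 and 3 differ in more than one place, so only their two values are compared. Compound 4 `CC1=C(C(=O)OCC2CCC2)C(c2ccco2)NC(=O)N1` carries the change (cyclobutylmethyl in place of sec-butyl on an oxygen next to a carbonyl group). Among the measured compounds shown here, the one step that bears on this position is a 20-fold higher number from compound 1 to compound 2 (1.31 log units; beyond the scatter), where a ring entered the ester chain; the ring entering here is non-aromatic and four-membered, so a smaller effect is expected. A modest weakening is expected, a 2.1-fold higher number from compound 3 to compound 4 (0.33 log units; beyond the scatter). Compound 4 is estimated at 180 nM in this assay, within 60 nM to 550 nM.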

Compound 4, inhibition constant: 561 nM
Compound 4: middle estimate off by 3.1-fold (0.49 log units), on the low side, outside the stated range (above it).
By their numbers in this assay, from the lowest: compound 3; then compounds 1 and 4 (each within the scatter of the next); then compound 2.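

In this assay, cyclobutylmethyl in place of sec-butyl on an oxygen next to a carbonyl group gives a 6.7-fold higher number from compound 3 to compound 4 (0.82 log units; beyond the scatter). A non-aromatic ring in the ester chain therefore also raises the number, alongside the phenyl step a 20-fold higher number from compound 1 to compound 2 (1.31 log units; beyond the scatter), so this effect is not confined to an aromatic ring. No measurement on hand explains the step. The ring and the added carbon enter together, so their contributions remain unseparated. An open-chain pentyl ester or a cyclopropylmethyl ester on the core of compound 3 would bear on that question.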